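The source may hold more compounds than are shown below. What is called first, only, known or untested is meant among the compounds shown, and "the series" means these compounds.

The measured compounds:
compound 1, `CCCc1ccc(NC(=O)C2CCN(C/C=C/c3ccccc3)CC2)cc1`, 5210 nM;
compound 2, `CC(C)c1ccc(NC(=O)C2CCN(C/C=C/c3ccccc3)CC2)cc1`, 5200 nM;
compound 3, `COc1ccc(NC(=O)C2CCN(C/C=C/c3ccccc3)CC2)cc1`, 58200 nM.

All three were run in a functional assay on MGC-803 cells (Homo sapiens) for inhibition, read by MTT assay, with a stated time of 72 h; on this read-out higher numbers stand for weaker inhibition and lower numbers for stronger inhibition. Compound 1 stands second highest of the three numbers; its nearest neighbour is compound 2, with a 1.0-fold lower number from compound 1 to compound 2 (0.00 log units; within the scatter), and the furthest is compound 3, with an 11-fold higher number from compound 1 to compound 3 (1.05 log units; beyond the scatter). Compound 4, `O=C(Nc1ccccn1)C1CCN(C/C=C/c2ccccc2)CC1`, has not yet been run. It differs from compound 1 in one place: pyridin-2-yl in place of 4-propylphenyl on an amide-type nitrogen. For the measured compounds named here, no measured step exchanges the whole aryl group, but an 11-fold higher number from compound 1 to compound 3 (1.05 log units; beyond the scatter) and an 11-fold higher number from compound 2 to compound 3 (1.05 log units; beyond the scatter) show that methoxy in place of propyl or isopropyl gave a large increase in this assay. With compound 4 the whole 4-propylphenyl leaves, so a large increase is expected, a 9.6-fold higher number from compound 1 to compound 4 (0.98 log units; beyond the scatter). Compound 4 is therefore estimated at 50000 nM, within 15000 nM to 150000 nM.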

Compound 4, half-maximal inhibitory concentration: 45200 nM
Compound 4: middle estimate off by 1.1-fold (0.04 log units), on the high side; the measured number falls inside the stated range.
By their numbers in this assay, from the lowest: compounds 2 and 1 (each within the scatter of the next); then compounds 4 and 3 (each within the scatter of the next).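

Exchanging the whole aryl group on the amide-type nitrogen can now be read directly in this assay: pyridin-2-yl gives an 8.7-fold higher number from compound 1 to compound 4 (0.94 log units; beyond the scatter) and an 8.7-fold higher number from compound 2 to compound 4 (0.94 log units; beyond the scatter) and so stands apart from both 4-propylphenyl and 4-isopropylphenyl. Against 4-methoxyphenyl, the same exchange gives a 1.3-fold lower number from compound 3 to compound 4 (0.11 log units; within the scatter) and so cannot be told apart at this position. Nothing available explains these steps.

The compounds shown leave open what a plain phenyl would give, and whether a propyl group or an amine on the pyridin-2-yl ring would bring the number back towards those of compound 1 and compound 2.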